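The source may hold more compounds than are shown below. What is called first, only, known or untested is meant among the compounds shown, and "the series" means these compounds.

Compound 1 `Cc1ccc(CS/C(=C/c2ccc(C)s2)C(=O)c2ccc(Cl)cc2)cc1` gives 50000 nM in a functional assay on DU-145 cells (Homo sapiens) for inhibition, read by trypan blue exclusion, with a stated time of 96 h; a lower number here means a stronger inhibitor of growth, a higher number a weaker inhibitor of growth. Compound 2 `O=C(/C(=C\c1ccc(O)cc1)SCc1ccc(F)cc1)c1ccc(Br)cc1` gives 10000 nM in this assay. Compound 3 `Cc1ccc(CS/C(=C/c2c[nH]c3ccc(Cl)cc23)C(=O)c2ccc(Cl)cc2)cc1` gives 1000 nM in this assay.

Among the three compounds measured so far, compound 3 stands lowest in this assay; compound 2 is its nearest neighbour and compound 1 the furthest, both beyond the scatter. Compound 4 `Cc1ccc(CS/C(=C/c2ccccc2F)C(=O)c2ccc(Cl)cc2)cc1` has not been measured yet. It differs from compound 3 in one place: 2-fluorophenyl in place of 5-chloro-1H-indol-3-yl on a double-bonded chain carbon bound to a double-bonded chain carbon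

Within the data shown here, the only measured step that bears on this position is a 50-fold lower number from compound 1 to compound 3 (1.70 log units; beyond the scatter), which shows how strongly the number depends on the group bound to the double-bonded chain carbon. Compound 2 carries a different group at the same place along with other changes and sits well above compound 3, so the two compounds without the 5-chloro-1H-indol-3-yl group both show higher numbers than compound 3. Since 2-fluorophenyl is a smaller ring than 5-chloro-1H-indol-3-yl and lacks its hydrogen-bond donor, the step from compound 3 to compound 4 is expected to go upward, estimated as a 20-fold higher number from compound 3 to compound 4 (1.30 log units; beyond the scatter), beyond the scatter but likely short of the step seen between compound 1 and compound 3. Compound 4 is therefore expected to give about 20000 nM in this assay, within a range of 5000 nM to 50000 nM.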

Compound 4, concentration for 50% growth inhibition: 10000 nM
Estimate against measurement, compound 4: 2.0-fold (0.30 log units) above; measured number inside the range.
By their numbers in this assay, from the lowest: compound 3; then compounds 2 and 4 (each within the scatter of the next); then compound 1.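

In this assay, among these compounds, the change at the double-bonded chain carbon bound to a double-bonded chain carbon now has a second measured step from compound 3, a 10-fold higher number from compound 3 to compound 4 (1.00 log units; beyond the scatter), and a first measured step that does not involve 5-chloro-1H-indol-3-yl, a 5.0-fold lower number from compound 1 to compound 4 (0.70 log units; beyond the scatter), so the three groups at this place stand apart from one another, with 5-chloro-1H-indol-3-yl giving the lowest number, 2-fluorophenyl the middle one and 5-methylthiophen-2-yl the highest. Among the compounds shown here, the number can therefore fall from compound 1 with a group that has no hydrogen-bond donor and only one six-membered aromatic ring, although that fall recovers only part of the distance to compound 3, and the large step from compound 1 to compound 3 is thus not an all-or-nothing effect of the 5-chloro-1H-indol-3-yl group. No measurement at hand gives a reason for this order of the three groups.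

The step from compound 3 to compound 4 changes the ring system, the halogen and the hydrogen-bond donor at once, so the compounds shown cannot say which of these carries the difference. An unsubstituted indol-3-yl, a plain phenyl or a 2-chlorophenyl at this place would begin to separate them, and the compounds shown leave open how an amine or a carboxylic acid on the ring would behave.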